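Ethyl for methyl on the piperazine of compound 3

The source may report more compounds than this note shows. Statements on the series, on what has been measured and on what is new or still open speak of the compounds shown alone.

Working notes on a small set of kinase inhibitors measured in an assay on isolated protein for inhibition of RAC-alpha serine/threonine-protein kinase (Homo sapiens), read by 33P incorporation, in the presence of a further agent that is not named here; on this read-out lower numbers stand for stronger inhibition and higher numbers for weaker inhibition. Compound 1 `CNc1ncc2c(-c3ccc(N4CCNCC4)nc3)nn(CC3CCCC3)c2n1` carries an unsubstituted piperazine. In this assay compound 1 gives > 10000 nM, which is a limit of the assay and not a number. Compound 3 `CNc1ncc2c(-c3ccc(N4CCN(C)CC4)nc3)nn(CC3CCCC3)c2n1` carries a methyl on the piperazine nitrogen. In this assay compound 3 gives > 10000 nM, again a limit of the assay. The step that the two limits leave unreadable from compound 1 to compound 3 is therefore not readable in size or direction. Compound 2 `CCN1CCN(c2ccc(-c3nn(Cc4cn(Cc5ccccc5)nn4)c4nc(NC)ncc34)cn2)CC1` carries an ethylpiperazine together with a different group on the ring nitrogen of the core; in this assay compound 2 gives 1900 nM, a measured number. Two of the three values sit at the limit of > 10000 nM in this assay, at which 2 of the 3 values shown sit, so compound 3 stands only as a limit, with one further limit beside it.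

Compound 4 `CCN1CCN(c2ccc(-c3nn(CC4CCCC4)c4nc(NC)ncc34)cn2)CC1` is not yet measured. It differs from compound 3 by methyl in place of hydrogen on a saturated chain carbon bound to an amine nitrogen in a ring. No measured step of this kind exists in the set; the only one-place step shown, from compound 1 to compound 3, is unreadable, and compound 2 differs from compound 4 in a second place. The step of a number no higher from compound 3 to compound 4 (the limit leaves the size open) is therefore expected to stay within the scatter. For compound 4 a value of 10000 nM is estimated, in the range 3000 nM to 30000 nM, most likely reported again as a limit.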

Compound 4, half-maximal inhibitory concentration: > 10000 nM
Compound 4 gave a limit, no number; the forecaster's own chance of this, stated with the estimate: 65%; the middle value sits exactly at the limit.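

In this assay compound 4 again returns a limit of the assay, not a number, so the steps to it from compound 1 and from compound 3 cannot be read in size or direction, and the change from 4-methylpiperazin-1-yl to 4-ethylpiperazin-1-yl has no measurable outcome with cyclopentyl on the chain. Going by these compounds alone, the first readable one-place step lies elsewhere: with the 4-ethylpiperazin-1-yl group held in common, cyclopentyl in place of 1-benzyl-1H-1,2,3-triazol-4-yl on a saturated chain carbon bound to an aromatic nitrogen gives an at least 5.2-fold higher number from compound 2 to compound 4 (0.72 log units; beyond the scatter). The cyclopentyl compounds now all stand at the limit, and the set as a whole is dominated by it: the limit of > 10000 nM in this assay, at which 3 of the 4 values shown sit.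

On these data alone, the true size of that step stays open, since one end of it is a limit, and so does any effect of the piperazine substituent when the 1-benzyl-1H-1,2,3-triazol-4-yl group is present. Whether hydrogen, methyl or a longer chain such as propyl on the piperazine nitrogen would shift the number of compound 2 cannot be told from the compounds shown.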